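Removing one methyl from the most active hydrazone

The source may report more compounds than this note shows. Statements on the series, on what has been measured and on what is new or still open speak of the compounds shown alone.

Measured so far in a functional assay on HT-29 cells (Homo sapiens) for antiproliferative activity, read by sulforhodamine B assay; a higher number here means a weaker inhibitor, a lower number a stronger inhibitor:
Compound 1 `C(=N/Nc1nc2ccccc2o1)\c1ccccn1` gives 1440 nM
Compound 2 `C/C(=N\Nc1nc2ccccc2o1)c1cnc(C)cn1` gives 290 nM
Compound 3 `c1ccc(C(=NNc2nc3ccccc3o2)c2ccccn2)nc1` gives 6980 nM

Of these three, compound 2 has the lowest number at 290 nM and is the strongest inhibitor. Compound 1 stands nearest at 1440 nM and compound 3 furthest at 6980 nM and both lie beyond the scatter from compound 2.

The next compound is compound 4 `C/C(=N\Nc1nc2ccccc2o1)c1cnccn1`, which departs from compound 2 in a single place. The change is hydrogen in place of methyl on an aromatic carbon and amounts to hydrogen in place of methyl on an aromatic carbon.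

Among the measured compounds shown here, no two measured compounds differ in only one place, so the data give no direct measure of this exchange. Compound 1 and compound 3 differ from compound 2 in more than one place and offer only loose guidance. With a single methyl exchanged, a modest move toward a higher number is expected. The estimated change is a 1.7-fold higher number from compound 2 to compound 4 (0.24 log units; within the scatter) and it is expected to stay close to the scatter. For compound 4 the estimated value is 500 nM with an expected range from 170 nM to 1500 nM in this measurement.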

Compound 4, half-maximal inhibitory concentration: 340 nM
Estimate against measurement, compound 4: 1.5-fold (0.17 log units) above; measured number inside the range.
By their numbers in this assay, from the lowest: compounds 2 and 4 (each within the scatter of the next); then compound 1; then compound 3.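

In this assay, hydrogen in place of methyl on an aromatic carbon of the six-membered aromatic ring with 2 nitrogen gives a 1.2-fold higher number from compound 2 to compound 4 (0.07 log units; within the scatter), and this is the first direct reading of this exchange among the compounds shown. Compound 2 gives 290 nM and compound 4 gives 340 nM, so at this place, next to the ring nitrogen and para to a large group, the methyl can give way to hydrogen with the two numbers staying within the scatter of each other, and in this pair the methyl is not required for a value in this range. No measurement is available that would explain this result.

The compounds shown hold only methyl and hydrogen at this place, so it remains open what an ethyl group, a methoxy group, an amine or a chlorine atom would give there. Going by these compounds, it also remains open whether the same exchange would read alike in another pair of compounds, as this single step is the only case at hand.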